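Chloro for methoxy, second instance in the series

This account rests on a few compounds, and the source may have more. Where it says the series, first, only, none or still open, it means among the compounds named here.

Compound 1 `COc1ccc(/N=C\c2cn(-c3ccc(Cl)cc3)nc2-c2ccc(C)cc2)cc1` and compound 2 `Cc1ccc(-c2nn(-c3ccc(Cl)cc3)cc2/C=N\c2ccc(Cl)cc2)cc1` differ in one place only, (chloro in place of methoxy on an aromatic carbon). In a functional assay on the whole organism (strain Wistar albino) for inhibition, with Rattus norvegicus as the target, read by paw edema, with stated times of 1 h and 2 h, at a dose of 0.32 mmol/kg by the intraperitoneal route (a lower number here means less inhibition, a higher number more inhibition at the dose given (going by the name of the read-out)), compound 1 gives 62%, and compound 2 gives 48.3%, a step of a number 13.7 percentage points lower from compound 1 to compound 2 (beyond the scatter). Compound 3 `COc1ccc(/N=C\c2cn(-c3ccc(Cl)cc3)nc2-c2ccc(OC)cc2)cc1` differs from compound 1 by methoxy in place of methyl on an aromatic carbon; in this assay compound 3 gives 69.2%, a step of a number 7.2 percentage points higher from compound 1 to compound 3 (within the scatter) that carries no weight on its own. Compound 4 `COc1ccc(-c2nn(-c3ccc(Cl)cc3)cc2/C=N\c2ccc(Cl)cc2)cc1` has not been measured. For the measured compounds named here, it differs from compound 3 by chloro in place of methoxy on an aromatic carbon, which is the same change as the one from compound 1 to compound 2, the place being described in identical words in both cases; the two cores differ only by the change already described between compound 1 and compound 3. For compound 4 the step of a number 14.2 percentage points lower from compound 3 to compound 4 (beyond the scatter) in this assay is expected to be close in size to the earlier one, because the same change once gave a number 13.7 percentage points lower from compound 1 to compound 2 (beyond the scatter). Compound 4 is therefore estimated at 55% in this assay, expected to fall between 44% and 66%.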

Compound 4, a percentage reported as inhibition, in the whole organism at one dose (the size of the read-out at that dose, not a potency): 69.6%
Estimate against measurement, compound 4: 14.6 percentage points below; the whole stated range lies below it.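

On the core of compound 3, chloro in place of methoxy on an aromatic carbon gives a step of a number 0.4 percentage points higher from compound 3 to compound 4 (within the scatter) in this assay, which does not match the earlier step for this change: the same change on two cores in this assay, a number 13.7 percentage points lower (beyond the scatter) from compound 1 to compound 2 and a number 0.4 percentage points higher (within the scatter) from compound 3 to compound 4, 14.1 percentage points apart, beyond the scatter of two such steps. Methoxy in place of methyl on an aromatic carbon, read across the same compounds, gives a step of a number 21.3 percentage points higher from compound 2 to compound 4 (beyond the scatter), and this also departs from its earlier counterpart: the same change on two cores in this assay, a number 7.2 percentage points higher (within the scatter) from compound 1 to compound 3 and a number 21.3 percentage points higher (beyond the scatter) from compound 2 to compound 4, 14.1 percentage points apart, beyond the scatter of two such steps. Both comparisons rest on the same four compounds, so they form a single finding: neither change carried over as a fixed step between cores in this series, but the data do not show why, nor whether this holds beyond these compounds.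

From the compounds shown here alone, what an amine or a carboxylic acid in the same place would do to the step remains open. Also open, going by these compounds, is whether the mismatch between cores would persist at other doses, since these numbers give the size of the read-out at one dose and not a potency.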